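The source may hold more compounds than are shown below. What is called first, only, known or untested is meant among the compounds shown, and "the series" means these compounds.

Measured so far:
compound 1 `COc1ncnc2c1c(-c1cc3ccccc3o1)cn2[C@@H]1O[C@H](CO)[C@@H](O)[C@H]1O`, 14500 nM
compound 2 `CNc1ncnc2c1c(-c1cc3ccccc3o1)cn2[C@@H]1O[C@H](CO)[C@@H](O)[C@H]1O`, > 20000 nM
compound 3 `CNc1ncnc2c1c(-c1ccco1)cn2[C@@H]1O[C@H](CO)[C@@H](O)[C@H]1O`, 440 nM

In a functional assay on HCT-116 cells (Homo sapiens), read by MTT assay, with a stated time of 72 h (a higher number here means a weaker inhibitor, a lower number a stronger inhibitor), compound 1 gives 14500 nM. For compound 2 this assay reports only a limit, > 20000 nM. Compound 3 gives 440 nM in this assay. The core of compound 2 and the core of compound 3 differ in one place: furan-2-yl in place of 1-benzofuran-2-yl on an aromatic carbon. That step, an at least 45-fold lower number from compound 2 to compound 3 (1.65 log units; beyond the scatter), is the large one in the set. Between compound 2 and compound 1 the change is methoxy in place of methylamino on an aromatic carbon, and the step of an at least 1.3-fold lower number from compound 2 to compound 1 (0.13 log units; that floor lies within the scatter) rests on the limit (the limit of > 20000 nM in this assay, at which 1 of the 3 values shown sits), so its true size is open.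

Compound 4 `COc1ncnc2c1c(-c1ccco1)cn2[C@@H]1O[C@H](CO)[C@@H](O)[C@H]1O` is not yet measured; it carries the same change on the core of compound 3: methoxy in place of methylamino on an aromatic carbon. Because the earlier step of an at least 1.3-fold lower number from compound 2 to compound 1 (0.13 log units; that floor lies within the scatter) is only a floor within the scatter, the expected step of a 1.4-fold higher number from compound 3 to compound 4 (0.13 log units; within the scatter) is kept small. Compound 4 is estimated at 600 nM in this assay, expected between 150 nM and 2500 nM.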

Compound 4, half-maximal inhibitory concentration: 40 nM
Beside the measured number, compound 4's estimate is 15-fold (1.18 log units) above it; measured number below the stated range.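

Methoxy in place of methylamino on an aromatic carbon gives an 11-fold lower number from compound 3 to compound 4 (1.04 log units; beyond the scatter) in this assay, whereas with 1-benzofuran-2-yl in the molecule only a floor can be read: the same change on two cores in this assay, an at least 1.3-fold lower number (0.13 log units; that floor lies within the scatter) from compound 2 to compound 1 and an 11-fold lower number (1.04 log units; beyond the scatter) from compound 3 to compound 4; the limit leaves it open whether they differ. The value of compound 2, > 20000 nM, is a limit of the assay, so the data do not show whether the change carries over with the same size. Furan-2-yl in place of 1-benzofuran-2-yl gives a 360-fold lower number from compound 1 to compound 4 (2.56 log units; beyond the scatter), so this change is large with methoxy and with methylamino, although its size with methylamino remains unsettled: the same change on two cores in this assay, an at least 45-fold lower number (1.65 log units; beyond the scatter) from compound 2 to compound 3 and a 360-fold lower number (2.56 log units; beyond the scatter) from compound 1 to compound 4; the limit leaves it open whether they differ.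

Still open, on these data alone, is whether ethoxy or a primary amine on this aromatic carbon would follow methoxy or methylamino. Also open, as far as these compounds go, is whether thiophen-2-yl or phenyl would follow furan-2-yl.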